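Swapping the aryl group on a brominated core

The source may hold more compounds than are shown below. What is called first, only, known or untested is meant among the compounds shown, and "the series" means these compounds.

Measured in a functional assay on HT-29 cells (Homo sapiens); a lower number here means a stronger inhibitor of growth, a higher number a weaker inhibitor of growth:
- Compound 1 (`O=S(=O)(/C=C/c1ccc(Cl)c(Cl)c1)Cc1ccc(Nc2ncnc3ccccc23)cc1`): 11000 nM
- Compound 2 (`O=S(=O)(/C=C/c1ccc(Br)cc1)Cc1ccc(Nc2ncnc3ccccc23)cc1`): > 100000 nM, a limit of the assay and not a number
- Compound 3 (`O=S(=O)(/C=C/c1ccc(Cl)c(Cl)c1)Cc1ccc(Nc2ncnc3ccc(Br)cc23)cc1`): 27000 nM

Compound 3 holds the higher of the two true numbers, with compound 1 its nearest neighbour. Compound 4 (`O=S(=O)(/C=C/c1ccc(Br)cc1)Cc1ccc(Nc2ncnc3ccc(Br)cc23)cc1`) carries 4-bromophenyl in place of the 3,4-dichlorophenyl of compound 3 (4-bromophenyl in place of 3,4-dichlorophenyl on a double-bonded chain carbon bound to a double-bonded chain carbon). The same swap gave an at least 9.0-fold higher number from compound 1 to compound 2 (0.95 log units; beyond the scatter). Adding bromo to the core gave a 2.5-fold higher number from compound 1 to compound 3 (0.39 log units; beyond the scatter), a modest change. A similar swap should therefore again raise the number, meaning weaker growth inhibition, and may well reach the limit of this assay. The expected step is a 3.7-fold higher number from compound 3 to compound 4 (0.57 log units; beyond the scatter). The estimate for compound 4 is 100000 nM, within an expected range of 40000 nM to 300000 nM.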

Compound 4, concentration for 50% growth inhibition: 10000 nM
Compound 4: the middle estimate sits 10-fold (1.00 log units) above what was measured; measured number below the stated range.
By their numbers in this assay, from the lowest: compounds 4 and 1 (each within the scatter of the next); then compound 3. At a limit, above all of these: compound 2.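

In this assay, the swap to 4-bromophenyl gives a 2.7-fold lower number from compound 3 to compound 4 (0.43 log units; beyond the scatter), so on the brominated core it runs opposite to its effect on the core of compound 1: the same change on two cores in this assay, an at least 9.0-fold higher number (0.95 log units; beyond the scatter) from compound 1 to compound 2 and a 2.7-fold lower number (0.43 log units; beyond the scatter) from compound 3 to compound 4, at least 24-fold (1.38 log units) apart, beyond the scatter of two such steps

Adding bromo to the core also changes direction with the aryl group present, giving an at least 10-fold lower number from compound 2 to compound 4 (1.00 log units; beyond the scatter): the same change on two cores in this assay, a 2.5-fold higher number (0.39 log units; beyond the scatter) from compound 1 to compound 3 and an at least 10-fold lower number (1.00 log units; beyond the scatter) from compound 2 to compound 4, at least 24-fold (1.38 log units) apart, beyond the scatter of two such steps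

Compound 2 gives > 100000 nM, which is a limit of the assay and not a number.

The compounds shown leave open whether this dependence of one change on the other holds for other groups on the core. An amine or a carboxylic acid in place of the bromo on the core would test this.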